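The compounds below may be only part of what the source reports. "The series", "measured", "known", "first", "only" and "open" are said of these compounds alone.

Measured compounds:
- compound 1 `COc1ccc(-c2cs/c(=N\NC(=O)c3ccc(O)cc3)n2-c2ccc(OC)cc2OC)cc1`: 3390 nM
- compound 2 `O=C(c1ccc(O)cc1)n1nc(-c2c(Cl)cccc2Cl)sc1=S`: 3310 nM
- compound 3 `Cc1ccc(-c2cs/c(=N\NC(=O)c3ccc(O)cc3)n2-c2c(C)cccc2C)cc1`: 11000 nM

In a functional assay on PC-3 cells (Homo sapiens) for cytotoxicity, read by sulforhodamine B assay, with a stated time of 48 h (a higher number here means a weaker inhibitor of growth, a lower number a stronger inhibitor of growth), compound 1 gives 3390 nM, the second highest of the three numbers. Compound 2, which carries a different core, gives 3310 nM, a number within the scatter of compound 1, so the two cannot be ordered. Compound 3 gives 11000 nM, a higher number than compound 1 and beyond the scatter; compound 3 differs from compound 1 in more than one place, so no single change can be tied to that gap.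

Compound 4 `COc1ccc(-n2c(-c3ccc(Cl)cc3)cs/c2=N\NC(=O)c2ccc(O)cc2)c(OC)c1` has not yet been measured in this assay. It differs from compound 1 in one place: chloro in place of methoxy on an aromatic carbon. Among the measured compounds shown here, no pair of measured compounds separated by only this change is available, so the size of the step cannot be read from the series. Given that compound 1 gives 3390 nM and that nothing in the measured compounds points to a large effect of this exchange, the expected step of a 1.1-fold lower number from compound 1 to compound 4 (0.05 log units; within the scatter) is small, not clearly beyond the scatter in either direction. The estimate for compound 4 in this assay is 3000 nM, with a range from 1000 nM to 9000 nM.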

Compound 4, concentration for 50% growth inhibition: 18200 nM
Beside the measured number, compound 4's estimate is 6.1-fold (0.78 log units) below it; measured number outside the range, above it.
By their numbers in this assay, from the lowest: compounds 2 and 1 (each within the scatter of the next); then compounds 3 and 4 (each within the scatter of the next).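

In this assay, among the compounds shown here, the exchange of 4-methoxyphenyl to 4-chlorophenyl gives a 5.4-fold higher number from compound 1 to compound 4 (0.73 log units; beyond the scatter) and is the first single change that can be read. The position on the aromatic carbon para to a large group therefore responds to the group it carries: with the rest of compound 1 held fixed, methoxy gives the stronger growth inhibition and chloro the weaker, and the step lies beyond the scatter. No measurement at hand accounts for this step, so it stands as an observation without an explanation.

From the compounds shown here alone, with one pair at this position, it remains open whether the step follows from the arrival of chloro or from the departure of methoxy; a plain phenyl, a 4-fluorophenyl, a 4-methylphenyl or a 4-aminophenyl at the same place would help to separate the two readings. Going by these compounds, it also remains open whether the same exchange would give a step of similar size with other groups elsewhere on the core of compound 1, since a single pair cannot show how far this result carries.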